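Nitro for tert-butyl in a series at the assay limit

The compounds below may be only part of what the source reports. "The series", "measured", "known", "first", "only" and "open" are said of these compounds alone.

In an ADME assay on Raji cells (Homo sapiens) for cytotoxicity, with a stated time of 72 h (a higher number here means that more compound is needed for the effect, a lower number that less compound is needed), compound 1 (`Cc1cc(NC(=O)Nc2ccc(C)c(Cl)c2)c2ccccc2n1`) gives > 25000 nM as a limit, not a number. Compound 2 (`Cc1cc(NC(=O)Nc2ccccc2C(C)(C)C)c2ccccc2n1`) gives > 25000 nM as a limit too. Compound 3 (`Cc1cc(NC(=O)Nc2ccc(N)cc2)c2ccccc2n1`) gives > 25000 nM as a limit as well.

Compound 2 therefore has no number of its own and stands with the other two measured compounds (the limit of > 25000 nM in this assay, at which 3 of the 3 values shown sit).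

Compound 4 (`Cc1cc(NC(=O)Nc2ccccc2[N+](=O)[O-])c2ccccc2n1`) has nitro in place of tert-butyl on an aromatic carbon, ortho to a large group (nitro in place of tert-butyl on an aromatic carbon). Going by the values given here, the series offers no measured step from which to size this change. On the evidence of compound 2 at > 25000 nM as a limit, no change beyond the usual scatter is expected in this assay, in either direction, and compound 4 is expected to remain at the limit.

The expected change is a number no higher from compound 2 to compound 4 (the limit leaves the size open) in this estimate. For compound 4 the estimated value is 25000 nM, with an expected range from 10000 nM to 25000 nM in this assay.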

Compound 4, half-maximal effective concentration: > 25000 nM
Compound 4: a limit, no number; the forecaster's own chance of this, stated with the estimate: 80%; the middle value sits exactly at the limit.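

Compound 2 and compound 4 both give only a limit in this assay, not a number, so no step can be read between them. The compounds shown leave open how far nitro and tert-butyl differ, and whether any compound in the series gives a number in this assay.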